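Aryl substituent change in a series at the assay limit

This account rests on a few compounds, and the source may have more. Where it says the series, first, only, none or still open, it means among the compounds named here.

Compound 2 `O=C(O)CCCSCCN1C(=O)SC[C@@H]1/C=C/[C@@H](O)Cc1cccc(C(F)(F)F)c1` stands only as a limit: in an assay on CHO cells for displacement of a labelled ligand from prostaglandin E2 receptor EP2 subtype (Mus musculus), read by scintillation counting, with a stated time of 60 min (a higher number here means a weaker inhibitor, a lower number a stronger inhibitor), compound 2 gives > 10000 nM. Compound 1 `CCCc1cccc(C[C@H](O)/C=C/[C@H]2CSC(=O)N2CCSCCCC(=O)O)c1` sits at the same limit, and in this assay compound 1 gives > 10000 nM. The step that the two limits leave unreadable from compound 1 to compound 2 is therefore unreadable, both ends resting on (the limit of > 10000 nM in this assay, at which 2 of the 2 values shown sit). Compound 3 `COCc1cccc(C[C@H](O)/C=C/[C@H]2CSC(=O)N2CCSCCCC(=O)O)c1` differs from compound 2 by methoxymethyl in place of trifluoromethyl on an aromatic carbon. No measured step reads, so no direction can be drawn from the numbers shown; with both measured compounds at the limit, compound 3 is expected to remain near it, the step that the limit leaves unreadable from compound 2 to compound 3 being the estimate. Compound 3 is expected at 15000 nM, between 3000 nM and 60000 nM.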

Compound 3, inhibition constant: > 10000 nM
Compound 3 gave a limit, no number (the forecaster's own chance of this, stated with the estimate: 75%); the middle value is on the limit's open side.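

No new step can be read among compound 1, compound 2 and compound 3, which all rest on one limit: the limit of > 10000 nM in this assay, at which 3 of the 3 values shown sit. The compounds shown leave open how propyl, trifluoromethyl and methoxymethyl rank against one another.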